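This account rests on a few compounds, and the source may have more. Where it says the series, first, only, none or still open, it means among the compounds named here.

In a functional assay on SW480 cells (Homo sapiens) for antiproliferative activity, read by sulforhodamine B assay, with a stated time of 48 h (a lower number here means a stronger inhibitor, a higher number a weaker inhibitor), compound 3 `COc1ccc(OC)c(/C=C/C(=O)C(=Cc2ccc(OC)c(OC)c2)C(=O)/C=C/c2cc(OC)ccc2OC)c1` gives 560 nM and sits within the scatter of both other measured compounds: compound 1 `COc1cccc(/C=C/C(=O)C(=Cc2cc(OC)c(OC)c(OC)c2)C(=O)/C=C/c2cccc(OC)c2OC)c1OC` gives 650 nM and compound 2 `COc1cccc(/C=C/C(=O)C(=Cc2ccc(O)c(F)c2)C(=O)/C=C/c2cccc(OC)c2OC)c1OC` gives 330 nM in the same series. Compound 4 `COc1ccc(OC)c(/C=C/C(=O)C(=Cc2ccc(OC)c(O)c2)C(=O)/C=C/c2cc(OC)ccc2OC)c1` differs from compound 3 by a single change hydrogen in place of methyl on an oxygen on an aromatic ring in which hydrogen takes the place of methyl on an oxygen on an aromatic ring, so methoxy becomes hydroxy and 3,4-dimethoxyphenyl becomes 3-hydroxy-4-methoxyphenyl. Within the data shown here, no measured pair makes exactly this change. The nearest guide is the step of a 2.0-fold lower number from compound 1 to compound 2 (0.29 log units; within the scatter) which also leads to a compound with a hydroxy group on a ring, yet it replaces a whole group and stays within the scatter. A small move toward a lower number in this assay is therefore expected, probably no larger than the scatter. The expected size is a 1.4-fold lower number from compound 3 to compound 4 (0.15 log units; within the scatter) and this remains only an estimate. Compound 4 is expected at 400 nM (estimated range 170 nM to 900 nM).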

Compound 4, half-maximal inhibitory concentration: 1120 nM
Estimate against measurement, compound 4: 2.8-fold (0.45 log units) below; measured number outside the range, above it.
By their numbers in this assay, from the lowest: compounds 2, 3, 1 and 4 (each within the scatter of the next, the first and the last beyond it).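

In this assay, putting hydrogen in place of methyl on an oxygen on an aromatic ring, so that 3,4-dimethoxyphenyl becomes 3-hydroxy-4-methoxyphenyl, gives a 2.0-fold higher number from compound 3 to compound 4 (0.30 log units; within the scatter). Among these compounds, this is the first view of this single change on its own, as the earlier step to a ring with a hydroxy group replaced a whole group, and here methoxy and hydroxy at this place cannot be told apart by this assay. Nothing shown here bears on what lies behind this reading.

Still open, on these data alone, is whether the same swap would read alike on the 3,4,5-trimethoxyphenyl ring of compound 1. Also open, as far as these compounds go, is how an amine or an ethoxy group at this place would compare with the methoxy of compound 3.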